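Chain lengthening on the carbinol carbon of the quinone core

The source may hold more compounds than are shown below. What is called first, only, known or untested is meant among the compounds shown, and "the series" means these compounds.

Measured so far in a functional assay on L1210 cells (Mus musculus) for cytotoxicity; a lower number here means that less compound is needed, a higher number that more compound is needed for the effect:
compound 1 `COc1cc(CO)c(OC)c2c1C(=O)C=CC2=O` gives 0.062 ug/mL
compound 2 `COc1cc(C(C)O)c(OC)c2c1C(=O)C=CC2=O` gives 0.132 ug/mL
compound 3 `CCCCCCC(O)c1cc(OC)c2c(c1OC)C(=O)C=CC2=O` gives 0.22 ug/mL

Compound 3 carries the highest number of the three. Its nearest neighbour is compound 2, and the difference between them, a 1.7-fold higher number from compound 2 to compound 3 (0.22 log units; within the scatter), is within the scatter; the gap to compound 1, a 3.5-fold higher number from compound 1 to compound 3 (0.55 log units; beyond the scatter), is beyond it.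

Compound 4 `CCCCCCCC(O)c1cc(OC)c2c(c1OC)C(=O)C=CC2=O` differs from compound 3 by methyl in place of hydrogen on a saturated chain carbon, seven bonds along the chain from an aromatic carbon and an oxygen on a saturated carbon. This is the same kind of change as the earlier ones, chain growth on the carbinol side chain, but placed at the far end of the chain. Among the measured compounds shown here, the steps that bear on it: a 2.1-fold higher number from compound 1 to compound 2 (0.33 log units; beyond the scatter), a modest rise; a 3.5-fold higher number from compound 1 to compound 3 (0.55 log units; beyond the scatter), a somewhat larger rise; and a 1.7-fold higher number from compound 2 to compound 3 (0.22 log units; within the scatter), which is within the scatter. Growth beyond the first carbon has so far added little, so a single extra carbon at the end of the chain is expected to give at most a small rise in this assay, likely not beyond the scatter.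

For compound 4 the expected step is a 1.3-fold higher number from compound 3 to compound 4 (0.10 log units; within the scatter), with an estimate of 0.28 ug/mL and a range from 0.14 ug/mL to 0.6 ug/mL.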

Compound 4, concentration for half-maximal effect: 0.274 ug/mL
For compound 4 the middle estimate is 1.0-fold (0.01 log units) above the measured one; the measured number falls inside the stated range.
By their numbers in this assay, from the lowest: compound 1; then compounds 2, 3 and 4 (each within the scatter of the next, the first and the last beyond it).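

In this assay, methyl in place of hydrogen on a saturated chain carbon, seven bonds along the chain, gives a 1.2-fold higher number from compound 3 to compound 4 (0.10 log units; within the scatter), so this single added carbon does not separate compound 4 from compound 3, and the same change on the carbon bound to the aromatic carbon cannot be told apart from it: the same change on two cores in this assay, a 2.1-fold higher number (0.33 log units; beyond the scatter) from compound 1 to compound 2 and a 1.2-fold higher number (0.10 log units; within the scatter) from compound 3 to compound 4, 1.7-fold (0.23 log units) apart, within the scatter of two such steps

Over a longer stretch of chain the picture differs, since hexyl in place of hydrogen two bonds along the chain gives a 2.1-fold higher number from compound 2 to compound 4 (0.32 log units; beyond the scatter), whereas the single steps among compounds 2, 3 and 4 each stay within the scatter, and this hexyl step agrees with the hexyl step on the carbon bound to the aromatic carbon: the same change on two cores in this assay, a 3.5-fold higher number (0.55 log units; beyond the scatter) from compound 1 to compound 3 and a 2.1-fold higher number (0.32 log units; beyond the scatter) from compound 2 to compound 4, 1.7-fold (0.23 log units) apart, within the scatter of two such steps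

With heptyl in place of hydrogen, a 4.4-fold higher number from compound 1 to compound 4 (0.65 log units; beyond the scatter) is the widest step in the series, and compound 1 keeps the lowest number, its steps to all three others lying beyond the scatter.

The compounds shown leave open whether a longer chain, such as decyl, would carry the number further up or leave it level. They also leave open how an amine or a carboxylic acid on the saturated chain carbon, seven bonds along the chain, would compare with methyl there.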